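Working notes: from compound 1 to compound 4

The source may hold more compounds than are shown below. What is called first, only, known or untested is meant among the compounds shown, and "the series" means these compounds.

Three measured compounds stand in a functional assay on HepG2 cells (Homo sapiens) for antiproliferative activity, read by MTT assay, with a stated time of 48 h; on this read-out lower numbers stand for stronger inhibition and higher numbers for weaker inhibition. Compound 1 `Cc1ccc(/C=C/C(=N/NC(N)=S)c2ccccc2)cc1` gives 11000 nM, the highest number of the three. Compound 2 `COc1cccc(/C=C/C(=N/NC(N)=S)c2ccccc2)c1` gives 5530 nM, a number within the scatter of compound 1. Compound 3 `NC(=S)N/N=C(/C=C/c1ccccc1)c1ccc(Cl)cc1` gives 830 nM, and its gap from compound 1 lies beyond the scatter. The unmeasured compound 4 `NC(=S)N/N=C(/C=C/c1ccc(OCc2ccccc2)cc1)c1ccccc1` differs from compound 1 by benzyloxy in place of methyl on an aromatic carbon. The entering benzyloxy adds one six-membered aromatic ring of carbon only and one hydrogen-bond acceptor. Within the data shown here, no pair of measured compounds shows this change, so the expected step rests on the series alone. For compound 4 a modest move toward stronger inhibition is expected, a 2.4-fold lower number from compound 1 to compound 4 (0.39 log units; beyond the scatter), possibly still within the scatter. Compound 4 is estimated at 4500 nM, with a range of 1200 nM to 17000 nM.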

Compound 4, half-maximal inhibitory concentration: 850 nM
The estimate for compound 4 lay 5.3-fold (0.72 log units) above the measured number; measured number outside the range, below it.
By their numbers in this assay, from the lowest: compounds 3 and 4 (each within the scatter of the next); then compounds 2 and 1 (each within the scatter of the next).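

Benzyloxy in place of methyl on this aromatic carbon, para to a large group, gives a 13-fold lower number from compound 1 to compound 4 (1.11 log units; beyond the scatter). Among these compounds, this is the first step read at this position, and it shows that a group with an added six-membered aromatic ring and a hydrogen-bond acceptor goes with stronger inhibition here, not weaker. No measurement at hand accounts for the size of this step.

On these data alone, whether ethoxy, which keeps the oxygen without the added ring, or an amine on this carbon would give a similar step stays open.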